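Returning the triazole diol in place of the pyrrolidine

The compounds below may be only part of what the source reports. "The series", "measured", "known", "first", "only" and "open" are said of these compounds alone.

For the measured compounds named here, compound 2 `O=C1c2c[n+]([O-])c3ccccc3c2C(=O)c2c1c1ccccc1n2CCN1CCCC1` gives the lowest of the three numbers so far in a functional assay on A549 cells (Homo sapiens) for cytotoxicity, read by MTT assay, with a stated time of 72 h (a lower number here means a stronger inhibitor, a higher number a weaker inhibitor), at 410 nM. Compound 3 `O=C1c2c[n+]([O-])c3ccccc3c2C(=O)c2c1c1ccccc1n2CCCCN1CCNCC1` gives 540 nM, a gap within the scatter, while compound 1 `O=C1c2c[n+]([O-])c3ccccc3c2C(=O)c2c1c1ccccc1n2Cc1cn(CC(O)CO)nn1` gives 880 nM, so that a 2.1-fold lower number from compound 1 to compound 2 (0.33 log units; beyond the scatter). Compound 4 `O=C1c2c[n+]([O-])c3ccccc3c2C(=O)c2c1c1ccccc1n2Cc1cn(C[C@@H](O)CO)nn1` differs from compound 2 as follows: 1-(2,3-dihydroxypropyl)-1H-1,2,3-triazol-4-yl in place of (pyrrolidin-1-yl)methyl on a saturated chain carbon bound to an aromatic nitrogen. This change is the reverse of the measured step of a 2.1-fold lower number from compound 1 to compound 2 (0.33 log units; beyond the scatter), with the entering group now carrying a defined stereocentre, whereas the steps of a 1.6-fold lower number from compound 1 to compound 3 (0.21 log units; within the scatter) and a 1.3-fold higher number from compound 2 to compound 3 (0.12 log units; within the scatter) add little beyond that. For compound 4 the expected step is therefore a 2.1-fold higher number from compound 2 to compound 4 (0.32 log units; beyond the scatter), towards a higher number. The estimate for compound 4 in this assay is 850 nM, within a range from 450 nM to 1600 nM.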

Compound 4, half-maximal inhibitory concentration: 390 nM
The estimate for compound 4 lay 2.2-fold (0.34 log units) above the measured number; the measured number lies below the stated range.
By their numbers in this assay, from the lowest: compounds 4, 2, 3 and 1 (each within the scatter of the next, the first and the last beyond it).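

In this assay, the 1-(2,3-dihydroxypropyl)-1H-1,2,3-triazol-4-yl group with a defined configuration does as well on this saturated chain carbon as the amine-bearing chains, with a 1.1-fold lower number from compound 2 to compound 4 (0.02 log units; within the scatter) and a 1.4-fold lower number from compound 3 to compound 4 (0.14 log units; within the scatter). The group as such therefore does not carry the penalty that compound 1 suggested. With the same atoms and bonds, the record shows a 2.3-fold lower number from compound 1 to compound 4 (0.35 log units; beyond the scatter), and what sets this pair apart is: the fact that one of compounds 1 and 4 is drawn with a defined configuration and the other without, at the place where they differ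

Going by these compounds, it remains open how the S configuration of the diol would read, and whether a carboxylic acid or a longer chain in place of the 2,3-dihydroxypropyl group would keep this number.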